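The compounds below may be only part of what the source reports. "The series", "measured", "known", "first", "only" and "open" are said of these compounds alone.

Working notes on the series

Three compounds have numbers in a functional assay on HepG2 cells (Homo sapiens) for cytotoxicity, read by sulforhodamine B assay, with a stated time of 48 h; a lower number here means a stronger inhibitor, a higher number a weaker inhibitor. Compound 1 `C/C(=N\NC(=O)C(C#N)C(=S)S)c1ccc(NS(=O)(=O)c2ccc(Cl)cc2)cc1` gives 17500 nM in this assay, and compound 2 `CCOC(=O)c1c(-c2ccccc2)c(C#N)c(=O)n(/N=C(\C)c2ccc(NS(=O)(=O)c3ccc(Cl)cc3)cc2)c1N` gives 16800 nM. Compound 3 `CCOC(=O)c1c(-c2ccc(C)cc2)c(C#N)c(=O)n(/N=C(\C)c2ccc(NS(=O)(=O)c3ccc(Cl)cc3)cc2)c1N` gives 8380 nM and so holds the lowest of the three numbers; against compound 2 its step is a 2.0-fold lower number from compound 2 to compound 3 (0.30 log units; within the scatter), which does not separate the two, while the gap to compound 1 is a little beyond the scatter.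

Compound 4 `CCOC(=O)c1c(-c2ccccc2OC)c(C#N)c(=O)n(/N=C(\C)c2ccc(NS(=O)(=O)c3ccc(Cl)cc3)cc2)c1N` is not yet measured. It differs from compound 3 by 2-methoxyphenyl in place of 4-methylphenyl on an aromatic carbon. Within the data shown here, the only measured step that touches this phenyl is the methyl addition from compound 2 to compound 3, and that step stayed within the scatter. Among the measured compounds shown here, no measured pair speaks to a methoxy group on this phenyl. With so little to go on, the expected step of a 1.4-fold higher number from compound 3 to compound 4 (0.16 log units; within the scatter) is none beyond the scatter, leaning slightly toward a higher number. That lean rests only on the methyl that leaves: compound 3, which carries it, gives 8380 nM in this assay. Compound 4 is therefore expected at about 12000 nM, between 5000 nM and 30000 nM.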

Compound 4, half-maximal inhibitory concentration: 11400 nM
Compound 4: the middle estimate sits 1.1-fold (0.02 log units) above what was measured; the measured number falls inside the stated range.
By their numbers in this assay, from the lowest: compounds 3, 4, 2 and 1 (each within the scatter of the next, the first and the last beyond it).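

Methoxy in place of hydrogen on this phenyl gives a 1.5-fold lower number from compound 2 to compound 4 (0.17 log units; within the scatter) and so, like the methyl step, does not separate from the scatter in this assay. The direct exchange of 4-methylphenyl for 2-methoxyphenyl gives a 1.4-fold higher number from compound 3 to compound 4 (0.13 log units; within the scatter) and is not separated either, so compound 2, compound 3 and compound 4 cannot be told apart, although the entering group adds an oxygen and a hydrogen-bond acceptor. No measurement at hand accounts for the size of these steps.

On these data alone, whether an amine, a carboxylic acid or a longer chain such as butoxy on this phenyl would give a step beyond the scatter remains open. Also open is how a methoxy group elsewhere on the phenyl would read, since the shown compounds carry it at one place only.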